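Compound 4: ethoxy in place of methyl

The compounds below may be only part of what the source reports. "The series", "measured", "known", "first", "only" and "open" are said of these compounds alone.

Compound 1 `Cc1ccc2nc(NC(=O)CCCCCCC(=O)NO)sc2c1`: 0.56 ug/mL
Compound 2 `Cc1ccc2nc(NC(=O)CCCCC(=O)NO)sc2c1`: 4.69 ug/mL
Compound 3 `O=C(CCCCC(=O)Nc1nc2ccc([N+](=O)[O-])cc2s1)NO`: > 30 ug/mL (a limit)

All three values come from a functional assay on SW-620 cells (Homo sapiens) for cytotoxicity; on this read-out lower numbers stand for stronger inhibition and higher numbers for weaker inhibition. Compound 1 gives 0.56 ug/mL, the lower of the two actual numbers. Its nearest neighbour is compound 2, and the shift is an 8.4-fold higher number from compound 1 to compound 2 (0.92 log units; beyond the scatter). Compound 3 gives > 30 ug/mL, which is a limit of the assay and not a number.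

Compound 4 `CCOc1ccc2nc(NC(=O)CCCCCCC(=O)NO)sc2c1` has not been measured yet. It keeps the chain of compound 1 and carries ethoxy in place of methyl on an aromatic carbon.

The step from a shorter to a longer chain does not touch this position, so it offers little guidance. Going by the values given here, the closest precedent is a different swap at an aromatic carbon, nitro in place of methyl, which gave an at least 6.3-fold higher number from compound 2 to compound 3 (0.80 log units; beyond the scatter). That step was taken on the shorter chain and with a different group, so it warns that such a swap can matter but does not set a size for ethoxy. Among the compounds with values here, no measured compound here carries ethoxy, so only a small rise in the number is expected in this assay. The estimated change is a 1.4-fold higher number from compound 1 to compound 4 (0.15 log units; within the scatter). For compound 4 the expected value is 0.8 ug/mL, with an estimated range of 0.3 ug/mL to 2.2 ug/mL.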

Compound 4, half-maximal inhibitory concentration: 10.4 ug/mL
Beside the measured number, compound 4's estimate is 13-fold (1.11 log units) below it; measured number outside the range, above it.
By their numbers in this assay, from the lowest: compound 1; then compound 2; then compound 4. At a limit, above all of these: compound 3.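

In this assay, the aromatic carbon that carries methyl proves sensitive on the longer chain as well as on the shorter one: ethoxy in place of methyl gives a 19-fold higher number from compound 1 to compound 4 (1.27 log units; beyond the scatter). The earlier swap at this carbon led to compound 3, whose value is a limit of the assay and not a number, so it gave no exact size for a change here: the limit of > 30 ug/mL in this assay, at which 1 of the 4 values shown sits. Compound 4 supplies the first exact size for a change at this carbon, although ethoxy differs from methyl both in its heavy atoms and in bringing a hydrogen-bond acceptor, and this one step cannot separate those two differences.

The compounds shown leave open whether the oxygen or the extra carbons matter more, and methoxy or propyl at this carbon on the same longer chain would help to tell these apart. Also open, going by these compounds, are how ethoxy behaves on the shorter chain of compound 2 and whether a smaller group, such as a fluorine atom or an amine, would be tolerated at this carbon.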